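A Trifluoromethyl Swap on a Weakly Binding Core

A few compounds are considered here, and "the series" means these few. Any claim that something is new, unique, unknown or untested is made for them only; others in the source may bear on it.

Compound 2 `CCCc1cccc(C[C@H](O)/C=C/[C@H]2CSC(=O)N2CCSCCCC(=O)O)c1` shows no measurable binding in an assay on CHO cells for displacement of a labelled ligand from prostaglandin E2 receptor EP1 subtype (Mus musculus), read by scintillation counting, with a stated time of 20 min; on this read-out lower numbers stand for stronger inhibition and higher numbers for weaker inhibition: compound 2 is reported only as the assay limit of > 10000 nM, not as a number. Compound 1 `O=C(O)CCCSCCN1C(=O)OC[C@@H]1/C=C/[C@@H](O)Cc1cccc(-c2ccccc2)c1` is likewise reported only as the limit > 10000 nM. For the measured compounds named here, both results sit at the limit of > 10000 nM in this assay, at which 2 of the 2 values shown sit, so no step between measured compounds can be sized. Compound 3 `O=C(O)CCCSCCN1C(=O)SC[C@@H]1/C=C/[C@@H](O)Cc1cccc(C(F)(F)F)c1` differs from compound 2 by trifluoromethyl in place of propyl on an aromatic carbon. With nothing measured to suggest a gain, the expected step that the limit leaves unreadable from compound 2 to compound 3 is none beyond the scatter. Compound 3 is therefore estimated at 15000 nM, within 5000 nM to 50000 nM, and most likely again reported only as a limit.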

Compound 3, inhibition constant: > 10000 nM
Compound 3 was reported as a limit; the forecaster's own chance of this, stated with the estimate: 80%; the middle value does not contradict the limit.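

For the compounds shown here, no step from compound 2 to compound 3 can be read in this assay, because each compound is reported only as a limit: (the limit of > 10000 nM in this assay, at which 3 of the 3 values shown sit). The compounds shown leave open whether swapping propyl for trifluoromethyl changes binding at all.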